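Chloro on the Phenyl Across Two Cores

This account rests on a few compounds, and the source may have more. Where it says the series, first, only, none or still open, it means among the compounds named here.

Compound 1 `CCc1nn(C)c2c1C(c1ccccc1)=NCC(=O)N2` and compound 2 `CCc1nn(C)c2c1C(c1ccccc1Cl)=NCC(=O)N2` share one core; compound 3 `Cc1nn(-c2ccccc2)c2c1C(c1ccccc1)=NCC(=O)N2` and compound 4 `Cc1nn(-c2ccccc2)c2c1C(c1ccccc1Cl)=NCC(=O)N2` share another, and the difference between the two cores is not broken down here. In a functional assay on the whole organism with Rattus norvegicus as the target (a higher number here means that more compound is needed for the effect, a lower number that less compound is needed), compound 1 gives 8 mg/kg, and compound 2 gives 32 mg/kg. The change between them, (chloro in place of hydrogen on an aromatic carbon), gave a 4.0-fold higher number from compound 1 to compound 2 (0.60 log units; beyond the scatter). For compound 3 in this assay only a limit is known, > 500 mg/kg, which is the limit of > 500 mg/kg in this assay, at which 1 of the 3 values shown sits. Compound 4 carries the same change, (chloro in place of hydrogen on an aromatic carbon), at the same place. Since the measured step of a 4.0-fold higher number from compound 1 to compound 2 (0.60 log units; beyond the scatter) raised the number, the expected step is a step that the limit leaves unreadable from compound 3 to compound 4, pushing compound 4 further past that limit. Compound 4 is therefore expected in this assay to give 2000 mg/kg, between 500 mg/kg and 8000 mg/kg, most likely reported again only as a limit.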

Compound 4, minimum effective dose: 500 mg/kg
For compound 4 the middle estimate is 4.0-fold (0.60 log units) above the measured one; low and high end bracket the measured number.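

In this assay, chloro in place of hydrogen (phenyl to 2-chlorophenyl) gives a number no higher from compound 3 to compound 4 (the limit leaves the size open), which does not repeat the rise seen on the other core: the same change on two cores in this assay, a 4.0-fold higher number (0.60 log units; beyond the scatter) from compound 1 to compound 2 and a number no higher (the limit leaves the size open) from compound 3 to compound 4, at least 4.0-fold (0.60 log units) apart, beyond the scatter of two such steps

Compound 3 is known only as a limit, > 500 mg/kg, so the size of the step on its core stays open: the limit of > 500 mg/kg in this assay, at which 1 of the 4 values shown sits.

For the compounds shown here, this shows that the step measured on one core cannot be carried over as a number to the other, but it does not show that chloro lowers the number on the core of compound 3, and each core offers only one pair.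

The compounds shown leave open which part of the difference between the two cores goes with this outcome. They also leave open how fluoro, methoxy or an amine at the same place would behave on either core.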